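Ether substituent and solubility, from compound 2 to compound 3

A few compounds are considered here, and "the series" means these few. Any claim that something is new, unique, unknown or untested is made for them only; others in the source may bear on it.

Notes on the shared core carrying different ether groups. Compound 1 `Nc1nccc(-c2cc(OC3CCCOC3)c3c(N)n[nH]c3c2)n1` bears an oxan-3-yl group on the ring oxygen, and in a physicochemical assay for solubility, read by LC-MS, in phosphate buffer, measured as kinetic solubility, with a stated time of 24 h, at 25 degrees C, at pH 7.4 (on this read-out higher numbers stand for higher solubility and lower numbers for lower solubility), compound 1 gives 1000000 nM. Compound 2 `COc1cc(-c2ccnc(N)n2)cc2[nH]nc(N)c12` bears a methyl group in the same place. In this assay compound 2 returns only a limit of the assay, > 100000 nM. The step that the limit leaves unreadable from compound 1 to compound 2 is therefore unreadable, since the result of compound 2 sits at the limit of > 100000 nM in this assay, at which 1 of the 2 values shown sits. On the numbers shown, compound 2 has no fixed position, only this limit. Compound 3 `Nc1nccc(-c2cc(OC3CCOCC3)c3c(N)n[nH]c3c2)n1` differs from compound 2 by oxan-4-yl in place of methyl on an oxygen on an aromatic ring. For the measured compounds named here, no measured step covers this exchange directly; the only step recorded involves the oxan-3-yl group and cannot be sized. The nearest reference is compound 1, whose ring ether gave 1000000 nM. Compound 3 is expected to reach about 800000 nM in this assay, within 250000 nM to 1500000 nM. The corresponding expected step is a step that the limit leaves unreadable from compound 2 to compound 3, read against a limit.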

Compound 3, solubility: 770000 nM
For compound 3 the middle estimate is 1.0-fold (0.02 log units) above the measured one, within the range that was stated.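

In this assay, oxan-4-yl in place of oxan-3-yl on the oxygen gives a 1.3-fold lower number from compound 1 to compound 3 (0.11 log units; within the scatter), so this exchange does not separate the two ring ethers on this read-out. Compound 2 remains a limit of the assay, > 100000 nM. The steps that involve compound 2 cannot be read, so the methyl group cannot be sized against either ring ether: the limit of > 100000 nM in this assay, at which 1 of the 3 values shown sits.

The compounds shown leave open whether the ring oxygen of the oxan groups matters, since neither cyclohexyl nor piperidin-4-yl appears on the same oxygen of the shared core. They also leave open how an open-chain group such as ethyl or 2-methoxyethyl would read in this assay.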